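Replacing Formyl with Chlorophenylethenyl on a Phenolic Core

A few compounds are considered here, and "the series" means these few. Any claim that something is new, unique, unknown or untested is made for them only; others in the source may bear on it.

Measured so far:
compound 1, `C=C[C@@](C)(/C=C/c1ccc(O)cc1)CC/C=C/C(=O)OCC`: > 36600 nM
compound 2, `C=C[C@@](C)(/C=C/c1ccc(O)c(C=O)c1)CCC=C(C)C`: > 36600 nM

In an ADME assay on HEK293 cells (Homo sapiens) for cytotoxicity, with a stated time of 72 h (a lower number here means that less compound is needed, a higher number that more compound is needed for the effect), compound 1 gives only a limit of the assay, > 36600 nM. Compound 2 likewise gives only a limit in this assay, > 36600 nM. Compound 2 therefore stands at the limit of > 36600 nM in this assay, at which 2 of the 2 values shown sit; neither value is a number, so the two compounds cannot be set in any order against each other, and the shared core of compound 2 is so far without a measured number at all.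

Compound 3, `C=C[C@@](C)(/C=C/c1ccc(O)c(/C=C/c2ccc(Cl)cc2)c1)CCC=C(C)C`, has not been measured. It differs from compound 2 in one place: 2-(4-chlorophenyl)ethenyl in place of formyl on an aromatic carbon. The change sits on an aromatic carbon of a six-membered aromatic ring of carbon only, ortho to a hydroxy group and meta to a large group.

Among the compounds with values here, no measured step accompanies this kind of change here. The step expected in this assay is an at least 1.2-fold lower number from compound 2 to compound 3 (0.08 log units; that floor lies within the scatter), which is none beyond the scatter, with a fair chance that compound 3 again returns only a limit. The estimate for compound 3 is 30000 nM, expected to lie between 10000 nM and 80000 nM.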

Compound 3, half-maximal effective concentration: > 36600 nM
Compound 3: only a limit was reported; the forecaster's own chance of this, stated with the estimate: 55%; middle value at least 1.2-fold (0.08 log units) from the limit.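

In this assay compound 3 gives only a limit, > 36600 nM. Compound 2 also gives only a limit, so no step can be read between compound 2 and compound 3, and the series shown stays at one limit: the limit of > 36600 nM in this assay, at which 3 of the 3 values shown sit.

The compounds shown leave open how compound 2 and compound 3 would rank if numbers replaced these limits.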